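Adding a Second Chloro to an Acetoxymethyl Enone

A few compounds are considered here, and "the series" means these few. Any claim that something is new, unique, unknown or untested is made for them only; others in the source may bear on it.

Of the compounds shown here, two have been tested so far. Compound 1 `O=C(/C(=C/c1ccc(Cl)cc1Cl)CCl)c1ccccc1` carries a chloromethyl group and two chloro groups on its aryl ring; in a functional assay on HeLa cells (Homo sapiens) for inhibition, read by sulforhodamine B assay, with a stated time of 48 h (a higher number here means a weaker inhibitor of growth, a lower number a stronger inhibitor of growth), compound 1 gives 15000 nM. Compound 2 `CC(=O)OC/C(=C\c1ccc(Cl)cc1)C(=O)c1ccccc1` instead carries an acetoxymethyl group and a single chloro group; in this assay compound 2 gives 3200 nM, the lower of the two numbers, and the gap between them lies beyond the usual scatter. Compound 1 and compound 2 differ in two places at once. Among the compounds with values here, no single step between them can be read off.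

Compound 3 `CC(=O)OC/C(=C\c1ccc(Cl)cc1Cl)C(=O)c1ccccc1` keeps the acetoxymethyl group of compound 2 and differs from it by chloro in place of hydrogen on an aromatic carbon, in words chloro in place of hydrogen on an aromatic carbon. Within the data shown here, with no measured step of this kind available, a modest change is expected, most likely a small weakening, giving a step of a 1.6-fold higher number from compound 2 to compound 3 (0.19 log units; within the scatter). Compound 3 is therefore estimated at 5000 nM, within a range from 1500 nM to 16000 nM.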

Compound 3, concentration for 50% growth inhibition: 16000 nM
For compound 3 the middle estimate is 3.2-fold (0.51 log units) below the measured one, within the range that was stated.
By their numbers in this assay, from the lowest: compound 2; then compounds 1 and 3 (each within the scatter of the next).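

In this assay, within the data shown here, the chloro ortho to a large group and meta to a chloro group is the first single change that can be read, and it gives a 5.0-fold higher number from compound 2 to compound 3 (0.70 log units; beyond the scatter), so this position on the aromatic ring is sensitive to replacing hydrogen with chloro when the acetoxymethyl group is present. With two chloro groups on the ring, placing acetoxy in place of chloro on the chain gives a 1.1-fold higher number from compound 1 to compound 3 (0.03 log units; within the scatter), so this exchange has no effect that can be told from scatter in this setting. Among these compounds, nothing measured so far offers an explanation for either result.

Going by these compounds, it remains open whether the same chloro step would weaken growth inhibition in a compound with the chloromethyl group. Also open, on these data alone, is how another group at this aromatic position, such as fluoro, methoxy or an amine, would compare with chloro.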